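The compounds below may be only part of what the source reports. "The series", "measured", "known", "first", "only" and "open" are said of these compounds alone.

Measured in an ADME assay on the whole organism (plasma) for pharmacokinetics, with Rattus norvegicus as the target; a lower number here means slower removal, a higher number faster removal of the compound:
- compound 1 `O=S(=O)(c1ccc(F)cc1)c1cc(Cl)c(O)c2ncccc12` gives 0.31 mL/min/kg
- compound 2 `O=S(=O)(c1ccc(F)cc1)c1cc(F)c(O)c2ncccc12` gives 12 mL/min/kg
- compound 3 `Cc1ccc(S(=O)(=O)c2cc(F)c(O)c3ncccc23)cc1` gives 27 mL/min/kg

Compound 1 stands lowest of the three. Compound 4 `O=S(=O)(c1cc(Cl)c(O)c2ncccc12)N1CCCC1` carries pyrrolidin-1-yl in place of 4-fluorophenyl on a sulfonyl sulfur. Among the measured compounds shown here, no measured step makes this change. The nearest is a 2.3-fold higher number from compound 2 to compound 3 (0.35 log units; beyond the scatter), a modest step that alters the same aromatic group but keeps it in place. The step of a 39-fold higher number from compound 1 to compound 2 (1.59 log units; beyond the scatter) is large and shows how far the number can move in this series, though it involves a different change. Since compound 1 sits so low at 0.31 mL/min/kg, a sizeable rise is expected, with wide uncertainty. The expected change is a 6.5-fold higher number from compound 1 to compound 4 (0.81 log units; beyond the scatter). For compound 4 the estimated clearance is 2 mL/min/kg, with an expected range of 0.4 mL/min/kg to 10 mL/min/kg.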

Compound 4, clearance: 1 mL/min/kg
Beside the measured number, compound 4's estimate is 2.0-fold (0.30 log units) above it; the measured number falls inside the stated range.
By their numbers in this assay, from the lowest: compound 1; then compound 4; then compound 2; then compound 3.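

In this assay, the sulfonyl sulfur tolerates loss of the aromatic ring: pyrrolidin-1-yl in place of 4-fluorophenyl gives a 3.2-fold higher number from compound 1 to compound 4 (0.51 log units; beyond the scatter) and remains a modest step. Among the compounds shown here, the earlier compounds varied only an aromatic group on this sulfur, so this is the first reading for a non-aromatic ring there. Nothing available accounts for the size of this step.

Still open, as far as these compounds go, is whether morpholine or a dimethylamino group on the sulfonyl sulfur would read like pyrrolidin-1-yl. Also open, from the compounds shown here alone, is whether pyrrolidin-1-yl gives a similar step with fluoro in place of chloro on the aromatic carbon.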